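This account rests on a few compounds, and the source may have more. Where it says the series, first, only, none or still open, it means among the compounds named here.

Working notes on the series. All three measured compounds share one core and differ only in the ring on the amide nitrogen. Compound 1 `O=C(CSc1nc(Nc2ccccc2)c2ccccc2n1)Nc1cccc([N+](=O)[O-])c1` gives 33000 nM in a functional assay on MDA-MB-231 cells (Homo sapiens) for inhibition, read by MTT assay, with a stated time of 72 h; on this read-out higher numbers stand for weaker inhibition and lower numbers for stronger inhibition. Compound 2 `COc1cccc(NC(=O)CSc2nc(Nc3ccccc3)c3ccccc3n2)c1` gives 21700 nM in this assay. Compound 3 `O=C(CSc1nc(Nc2ccccc2)c2ccccc2n1)Nc1ccc(F)cc1` gives 34100 nM in this assay. The three numbers sit together: the step from compound 1 to compound 2 is a 1.5-fold lower number from compound 1 to compound 2 (0.18 log units; within the scatter), the step from compound 1 to compound 3 is a 1.0-fold higher number from compound 1 to compound 3 (0.01 log units; within the scatter), and the step from compound 2 to compound 3 is a 1.6-fold higher number from compound 2 to compound 3 (0.20 log units; within the scatter). On the numbers shown, compound 3 is therefore not separable from compound 1 or compound 2; every change of the amide-bound ring so far has stayed within the scatter.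

Compound 4 `O=C(CSc1nc(Nc2ccccc2)c2ccccc2n1)Nc1ccc(Br)cc1` differs from compound 3 by bromo in place of fluoro on an aromatic carbon. Going by the values given here, no measured step exchanges one halogen for another. Among the compounds with values here, the steps that bear on the amide-bound ring at all are a 1.0-fold higher number from compound 1 to compound 3 (0.01 log units; within the scatter) and a 1.6-fold higher number from compound 2 to compound 3 (0.20 log units; within the scatter), both within the scatter, and they give no ground for expecting a step beyond the scatter here. Compound 4 is therefore expected to come out at 30000 nM, with a range from 12000 nM to 75000 nM. The implied step, a 1.1-fold lower number from compound 3 to compound 4 (0.06 log units; within the scatter), is expected to stay within the scatter.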

Compound 4, half-maximal inhibitory concentration: 11500 nM
Compound 4: the middle estimate sits 2.6-fold (0.42 log units) above what was measured, and the stated range ends above it.
By their numbers in this assay, from the lowest: compounds 4, 2, 1 and 3 (each within the scatter of the next, the first and the last beyond it).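

In this assay, going by these compounds alone, bromo in place of fluoro gives a 3.0-fold lower number from compound 3 to compound 4 (0.47 log units; beyond the scatter) and is the first single-place change to go beyond the scatter, which shows that the amide-bound ring can respond to the exchange of one halogen for another on an aromatic carbon para to a large group. The 4-bromophenyl ring also separates modestly from the 3-nitrophenyl ring, with a 2.9-fold lower number from compound 1 to compound 4 (0.46 log units; beyond the scatter) beyond the scatter, but not from the 3-methoxyphenyl ring, with a 1.9-fold lower number from compound 2 to compound 4 (0.28 log units; within the scatter) within the scatter, so the gain over the other rings is not general and compound 4 cannot be ranked above compound 2. Nothing on hand bears on what lies behind these steps.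

Chloro or iodo on the same aromatic carbon would show whether the numbers follow the halogen series or whether bromo stands alone, and a methyl group, an amine or a carboxylic acid there would test whether a halogen is needed at all. Going by these compounds, it also stays open whether the bromo step carries over when the phenylamino group on the shared core is replaced, for instance by a benzylamino group.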